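Three Inactive Analogues and a Chloro-Methyl Replacement

This account rests on a few compounds, and the source may have more. Where it says the series, first, only, none or still open, it means among the compounds named here.

Compound 1: `Cc1ccccc1-n1nncc1CN1C(=O)C2(C(C#N)=C(N)Oc3c2c2nc4ccccc4nc2c2ccccc32)c2ccccc21` — in an ADME assay on HUVEC cells (Homo sapiens) for antiproliferative activity, read by MTT assay, with a stated time of 48 h (on this read-out higher numbers stand for weaker inhibition and lower numbers for stronger inhibition), compound 1 gives > 50000 nM, which is a limit of the assay and not a number.
Compound 2: `Cc1cc(C)cc(-n2nncc2CN2C(=O)C3(C(C#N)=C(N)Oc4c3c3nc5ccccc5nc3c3ccccc43)c3ccccc32)c1` — in this assay compound 2 gives > 50000 nM, again a limit rather than a number.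
Compound 3: `COc1ccccc1-n1nncc1CN1C(=O)C2(C(C#N)=C(N)Oc3c(N)cc4nc5ccccc5nc4c32)c2ccccc21` — in this assay compound 3 gives > 50000 nM, also a limit and not a number.

All three measured compounds share a core and differ only in the aryl group on the triazole nitrogen. Compound 3 stands at the limit, as do the other two values, so no ordering among them can be read. Going by the values given here, the only step between measured compounds, a step that the two limits leave unreadable from compound 1 to compound 2, cannot be sized, since both ends sit at the limit, as the limit of > 50000 nM in this assay, at which 3 of the 3 values shown sit, records.

Compound 4 is `Cc1ccc(Cl)cc1-n1nncc1CN1C(=O)C2(C(C#N)=C(N)Oc3c(N)cc4nc5ccccc5nc4c32)c2ccccc21`. The change from compound 3 is 5-chloro-2-methylphenyl in place of 2-methoxyphenyl on an aromatic nitrogen. No measured step bears on this exchange in a readable way, and the one shown step was itself unreadable, so no direction beyond the scatter is expected in this assay. Compound 4 is therefore expected to remain weak, with an estimated value of 70000 nM (range 30000 nM to 200000 nM), meaning an expected step that the limit leaves unreadable from compound 3 to compound 4, and most likely the assay will again report only a limit.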

Compound 4, half-maximal inhibitory concentration: > 50000 nM
Compound 4 was reported as a limit; the forecaster's own chance of this, stated with the estimate: 85%; the middle value does not contradict the limit.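

The step from compound 3 to compound 4 cannot be read, since both ends are limits and not numbers: the limit of > 50000 nM in this assay, at which 4 of the 4 values shown sit. How the aryl groups on the aromatic nitrogen rank against one another in this assay stays open, as no compound shown has a readable number.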